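The source may hold more compounds than are shown below. What is called first, only, known or untested is meant among the compounds shown, and "the series" means these compounds.

Compound 1 `CCCC(=O)Nc1ccc(S(=O)(=O)Oc2ccccc2I)cc1` carries a butanoyl amide on the shared core and, in a functional assay on HT-29 cells (Homo sapiens) for antiproliferative activity, read by sulforhodamine B assay, with a stated time of 48 h (on this read-out higher numbers stand for weaker inhibition and lower numbers for stronger inhibition), compound 1 gives 11000 nM. Compound 2 `O=C(CCCCl)Nc1ccc(S(=O)(=O)Oc2ccccc2I)cc1` differs only at the end of that chain, and in this assay compound 2 gives 9100 nM. The change between them, a 1.2-fold lower number from compound 1 to compound 2 (0.08 log units; within the scatter), is too small to separate the two; on the numbers shown, compound 2 sits alongside compound 1 rather than apart from it.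

Compound 3 `O=C(NCC1CCCC1)Nc1ccc(S(=O)(=O)Oc2ccccc2I)cc1` has not been measured. It differs from compound 2 by (cyclopentylmethyl)amino in place of 3-chloropropyl on a carbonyl carbon, so the amide-type nitrogen now sits on a (cyclopentylmethyl)carbamoyl group instead of a (3-chloropropyl)carbonyl group. Among the compounds with values here, only one measured step bears on this place, the one from compound 1 to compound 2, and it stayed within the scatter while touching the far end of the same chain. That gives no sign that the tail on this carbonyl carbon drives the read-out, though the present change is larger and adds a ring and a hydrogen-bond donor. The number for compound 3 is therefore expected to lie near that of compound 2, the expected step being a 1.1-fold lower number from compound 2 to compound 3 (0.06 log units; within the scatter). In this assay compound 3 is estimated at 8000 nM, within a range of 2500 nM to 25000 nM.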

Compound 3, half-maximal inhibitory concentration: 7600 nM
Beside the measured number, compound 3's estimate is 1.1-fold (0.02 log units) above it, within the range that was stated.
By their numbers in this assay, from the lowest: compounds 3, 2 and 1 (each within the scatter of the next).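

Compound 3 swaps 3-chloropropyl for (cyclopentylmethyl)amino on the carbonyl carbon, bringing in a five-membered non-aromatic ring of carbon only and a hydrogen-bond donor, yet this assay shows a 1.2-fold lower number from compound 2 to compound 3 (0.08 log units; within the scatter) for this change. Set against the plain propyl group, the same tail gives a 1.4-fold lower number from compound 1 to compound 3 (0.16 log units; within the scatter) and again stays inside the usual spread of repeat measurements, so this place accepts a much bigger change than the chloro step without compounds 1, 2 and 3 coming apart. Nothing at hand offers an explanation for this flat result.

From the compounds shown here alone, the ring and the nitrogen enter together in compound 3, so their separate shares stay unknown, and a propylamino group on the same carbonyl carbon would carry the nitrogen without the ring. All three tails shown carry no net charge and none holds an aromatic ring, so it remains open whether an amine, a carboxylic acid or a benzyl group at this place would move the number beyond the scatter.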